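Compound 4: 6-hydroxypyridin-3-yl in place of 4-fluorophenyl

The compounds below may be only part of what the source reports. "The series", "measured", "known", "first", "only" and "open" are said of these compounds alone.

Compound 1, `O=C(Nc1ccc(NCC2CCCC2)cc1Cl)c1cc(Cl)ccc1O`, in an ADME assay on A549 cells (Homo sapiens) for cytotoxicity, read by resazurin assay, with a stated time of 48 h; a lower number here means that less compound is tolerated, a higher number that more compound is tolerated: 21500 nM
Compound 2, `O=C(Nc1ccc(N(CC2CC2)CC2CC2)cc1Cl)c1cc(Cl)ccc1O`, in this assay: 12800 nM
Compound 3, `O=C(Nc1ccc(NCc2ccc(F)cc2)cc1Cl)c1cc(Cl)ccc1O`, in this assay: 54400 nM

Among these three, compound 3 stands highest in this assay, and both of its steps from the others lie beyond the scatter: a 2.5-fold higher number from compound 1 to compound 3 (0.40 log units; beyond the scatter) and a 4.3-fold higher number from compound 2 to compound 3 (0.63 log units; beyond the scatter). The step between compound 1 and compound 2 is smaller, a 1.7-fold lower number from compound 1 to compound 2 (0.23 log units; within the scatter).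

Compound 4, `O=C(Nc1ccc(NCc2ccc(O)nc2)cc1Cl)c1cc(Cl)ccc1O`, has not yet been measured. It differs from compound 3 in one place: 6-hydroxypyridin-3-yl in place of 4-fluorophenyl on a saturated chain carbon bound to a nitrogen on an aromatic ring. For the measured compounds named here, none of the measured steps exchanges one aromatic ring for another at this position; the two steps that touch this position both replace a saturated ring with the 4-fluorophenyl group, and both were modest. Going by the values given here, there is therefore no direct precedent, and the expectation is a step of no size beyond the scatter, a 1.1-fold higher number from compound 3 to compound 4 (0.04 log units; within the scatter). Compound 4 is estimated to give about 60000 nM in this assay, with a range from 25000 nM to 150000 nM.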

Compound 4, half-maximal cytotoxic concentration: 98500 nM
Beside the measured number, compound 4's estimate is 1.6-fold (0.22 log units) below it, within the range that was stated.
By their numbers in this assay, from the lowest: compounds 2 and 1 (each within the scatter of the next); then compounds 3 and 4 (each within the scatter of the next).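

In this assay the change of 4-fluorophenyl to 6-hydroxypyridin-3-yl on a saturated chain carbon bound to a nitrogen on an aromatic ring gives a 1.8-fold higher number from compound 3 to compound 4 (0.26 log units; within the scatter) and so shows that this position takes one aromatic ring in place of another, here one with a hetero atom and a hydrogen-bond donor, without a step beyond the scatter. The saturated groups lie further off, with a 4.6-fold higher number from compound 1 to compound 4 (0.66 log units; beyond the scatter) on exchanging cyclopentyl and a 7.7-fold higher number from compound 2 to compound 4 (0.89 log units; beyond the scatter) on exchanging the whole amino group. Both aromatic compounds, compound 3 and compound 4, therefore stand clear of compound 1 and compound 2 with no listed compound against this.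

On these data alone, it remains open how an unsubstituted benzyl, a pyridine ring bearing an amine or a carboxylic acid instead of the hydroxyl, or a longer chain to the ring would stand. No evidence here says what lies behind these steps.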